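Two Limits and a Chlorine Swap

The source may report more compounds than this note shows. Statements on the series, on what has been measured and on what is new or still open speak of the compounds shown alone.

Compound 1 `Cc1ccccc1NNC(=O)c1ccc(NS(=O)(=O)c2cnc(O)nc2O)cc1`: > 20000 nM
Compound 2 `Cc1ccccc1C(=O)NNC(=O)c1ccc(NS(=O)(=O)c2cnc(O)nc2O)cc1`: > 20000 nM

In a functional assay on OVCAR-3 cells (Homo sapiens) for antiproliferative activity, read by MTT assay, with a stated time of 24 h (a lower number here means a stronger inhibitor, a higher number a weaker inhibitor), compound 2 gives > 20000 nM, which is a limit of the assay and not a number. Compound 1 gives > 20000 nM, which is also a limit. The evidence so far is simply (the limit of > 20000 nM in this assay, at which 2 of the 2 values shown sit).

The next compound, compound 3 `O=C(NNC(=O)c1cccc(Cl)c1)c1ccc(NS(=O)(=O)c2cnc(O)nc2O)cc1`, has 3-chlorophenyl in place of 2-methylphenyl on a carbonyl carbon, and the rest of compound 2 stays the same: 3-chlorophenyl in place of 2-methylphenyl on a carbonyl carbon.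

Going by the values given here, only one measured step bears on this change, and only indirectly: a step that the two limits leave unreadable from compound 1 to compound 2. Among the compounds with values here, it gives no size to carry over, so no particular step or direction can be expected in this assay. The most likely outcome is that compound 3 again reaches only a limit rather than a readable number. For compound 3 the estimated value is 30000 nM, with an expected range of 12000 nM to 80000 nM. The expected change is a step that the limit leaves unreadable from compound 2 to compound 3.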

Compound 3, half-maximal inhibitory concentration: 7710 nM
Estimate against measurement, compound 3: 3.9-fold (0.59 log units) above; the measured number lies below the stated range.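

In this assay, going by these compounds alone, the swap on the carbonyl carbon yields the first readable number in the set, with an at least 2.5-fold lower number from compound 2 to compound 3 (0.41 log units; beyond the scatter), so the ring group at this position can shift the result. Neither 2-methylphenyl nor 3-chlorophenyl carries a hydrogen-bond donor or acceptor, so those counts do not separate the two groups. Putting (3-chlorophenyl)carbonyl in place of 2-methylphenyl on an amine nitrogen gives an at least 2.5-fold lower number from compound 1 to compound 3 (0.41 log units; beyond the scatter), and both of these sizes are lower bounds on the true change. The step between the other two compounds cannot be read, and limits still make up most of the picture: the limit of > 20000 nM in this assay, at which 2 of the 3 values shown sit.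

The compounds shown cannot separate the arrival of the chlorine from the departure of the methyl and its different place in the group, since the two changes come together in a single swap. They also leave open what a fluorine, a methoxy group or a carboxylic acid would do in place of that chlorine on the same ring, and whether any such group would move the number further in either direction.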